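Cyano for isopropyl on the aryl of compound 2

This account rests on a few compounds, and the source may have more. Where it says the series, first, only, none or still open, it means among the compounds named here.

Two members of this series carry a measured value in an assay on HEK293 cells for agonist activity at Free fatty acid receptor 1 (Homo sapiens), read by a beta-galactosidase reporter and beta-arrestin recruitment, with a stated time of 90 min, in the presence of a further agent that is not named here; on this read-out lower numbers stand for an effect already at smaller amounts and higher numbers for an effect only at larger amounts of compound. Compound 1 `CC#C[C@@H](CC(=O)O)c1ccc(OCc2ccc3nc(-c4c(C)cc(OCCCS(C)(=O)=O)cc4C)nn3c2)cc1` gives 1490 nM in this assay. Compound 2 `CC#C[C@@H](CC(=O)O)c1ccc(OCc2ccc3nc(-c4ccc(C(C)C)cc4)nn3c2)cc1` gives 67 nM in this assay, the lowest of the two numbers shown, and the gap to compound 1 lies beyond the scatter. Among the measured compounds shown here, no single-point step between measured compounds is available, so the comparison rests on these two values alone.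

Compound 3 `CC#C[C@@H](CC(=O)O)c1ccc(OCc2ccc3nc(-c4ccc(C#N)cc4)nn3c2)cc1` is not yet measured in this assay. It differs from compound 2 by cyano in place of isopropyl on an aromatic carbon, para to a large group. For the measured compounds named here, the only comparison on hand, compound 1 against compound 2, shows that a change at this outer aryl can move the number well beyond the scatter. For compound 3 a loss beyond the scatter is expected, with the step of a 3.7-fold higher number from compound 2 to compound 3 (0.57 log units; beyond the scatter) estimated as moderate. Compound 3 is expected at 250 nM, estimated between 60 nM and 1000 nM.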

Compound 3, half-maximal effective concentration: 443 nM
The estimate for compound 3 lay 1.8-fold (0.25 log units) below the measured number; the measured number falls inside the stated range.
By their numbers in this assay, from the lowest: compound 2; then compound 3; then compound 1.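

In this assay, among the compounds shown here, cyano in place of isopropyl on an aromatic carbon, para to a large group, gives a 6.6-fold higher number from compound 2 to compound 3 (0.82 log units; beyond the scatter), the first step that can be read at a single place. With the shared core unchanged, the exchange of 4-isopropylphenyl for 4-cyanophenyl alone moves the number beyond the scatter, so this position does not tolerate every group equally. Nothing on hand explains the rise.

Open, as far as these compounds go, is whether the rise belongs to the loss of the branched alkyl group or to the nitrile itself: a methyl, a tert-butyl or a methoxy group on this carbon would separate the two readings. Compound 1 differs from compound 2 and compound 3 in more than one place, so it says nothing specific about this carbon.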